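Compound 4: same atoms as compound 2, joined differently

A few compounds are considered here, and "the series" means these few. Any claim that something is new, unique, unknown or untested is made for them only; others in the source may bear on it.

Of the compounds shown here, three have been tested in an ADME assay on MT4 cells (Homo sapiens) for cytotoxicity, read by MTT assay, with a stated time of 4 days; on this read-out higher numbers stand for lower toxicity in this test and lower numbers for higher toxicity in this test: compound 1 `O=C(c1cc(F)cc(F)c1)c1cc(Cl)ccc1OCCn1ccc(=O)[nH]c1=O`, compound 2 `Cc1cc(C)cc(C(=O)c2cc(Cl)ccc2OCCn2cc(C)c(=O)[nH]c2=O)c1` and compound 3 `O=C(c1ccccc1)c1cc(F)ccc1OCCn1ccc(=O)[nH]c1=O`. Compound 2 gives > 303000 nM in this assay, which is a limit of the assay and not a number. Compound 1 gives > 307000 nM, also a limit. Compound 3 gives > 353000 nM, again a limit. Compound 2 therefore stands with the other two, and none of the three has a numerical value.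

Compound 4 `Cc1cc(C)cc(C(=O)c2cc(Cl)ccc2OCCn2c(C)cc(=O)[nH]c2=O)c1` has the same atoms as compound 2, joined differently: a group of 9 heavy atoms (5 carbon, 2 nitrogen, 2 oxygen; one six-membered aromatic ring with 2 hetero atoms) in place of a group of 9 heavy atoms (5 carbon, 2 nitrogen, 2 oxygen; one six-membered aromatic ring with 2 hetero atoms), on a saturated chain carbon, two bonds along the chain from an oxygen on an aromatic ring. The expectation rests on compound 2, whose > 303000 nM is a limit. The estimate is a number no higher from compound 2 to compound 4 (the limit leaves the size open), meaning that no change in either direction is expected beyond the usual scatter in this assay. A limit is the most likely report for the new measurement. Compound 4 is expected at about 300000 nM, within an estimated range from 120000 nM to 400000 nM.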

Compound 4, half-maximal cytotoxic concentration: > 303000 nM
Compound 4: only a limit was reported; the forecaster's own chance of this, stated with the estimate: 75%; at least 1.0-fold (0.00 log units) between middle value and limit.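

No step can be read from compound 2 to compound 4, because each carries only a limit and not a number: the limit of > 303000 nM in this assay, at which 2 of the 4 values shown sit.

The compounds shown leave open whether this rearranged group changes cytotoxicity at all, and what half-maximal cytotoxic concentration any of the four actually has.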